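The compounds below may be only part of what the source reports. "The series", "measured", "known", "first", "only" and "open" are said of these compounds alone.

Of the compounds shown here, three built on one shared core have been measured in an in vitro assay on cells for inhibition of Amine oxidase [flavin-containing] B (Homo sapiens), read by fluorescence and Amplex Red, with stated times of 30 min and 45 min; on this read-out higher numbers stand for weaker inhibition and lower numbers for stronger inhibition. Compound 1 `COc1cccc(/C=C/C(=O)Nc2nc3ccccc3c(=O)s2)c1` gives 470 nM in this assay. Compound 2 `COc1cccc(CCCC(=O)Nc2nc3ccccc3c(=O)s2)c1` gives 389 nM; its gap to compound 1 lies within the scatter, and the difference between the two cores is not broken down here. Compound 3 `O=C(CCCc1cccc(Cl)c1)Nc1nc2ccccc2c(=O)s1` reaches only the limit of > 1000 nM in this assay, so it carries no number. From compound 2 to compound 3 the change chloro in place of methoxy on an aromatic carbon produced an at least 2.5-fold higher number from compound 2 to compound 3 (0.41 log units; beyond the scatter), a step that rests on (the limit of > 1000 nM in this assay, at which 1 of the 3 values shown sits). Compound 4 `O=C(/C=C/c1cccc(Cl)c1)Nc1nc2ccccc2c(=O)s1` has not yet been measured. It differs from compound 1 by chloro in place of methoxy on an aromatic carbon, the same change that took compound 2 to compound 3. Because compound 1 stands at 470 nM and the earlier step was an at least 2.5-fold higher number from compound 2 to compound 3 (0.41 log units; beyond the scatter), compound 4 is expected to give a clearly higher number than compound 1 in this assay. The step expected is a 2.8-fold higher number from compound 1 to compound 4 (0.44 log units; beyond the scatter). Compound 4 is estimated at about 1300 nM. Compound 4 is expected to fall between 500 nM and 4000 nM.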

Compound 4, half-maximal inhibitory concentration: 93.3 nM
Compound 4: middle estimate off by 14-fold (1.14 log units), on the high side; measured number outside the range, below it.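

In this assay, replacing the 3-methoxyphenyl group with 3-chlorophenyl on the core of compound 1 gave a 5.0-fold lower number from compound 1 to compound 4 (0.70 log units; beyond the scatter), so chloro gives stronger inhibition than methoxy on this core. The same swap went the opposite way on the core of compound 2, which shows that its effect did not carry over from one core to the other: the same change on two cores in this assay, an at least 2.5-fold higher number (0.41 log units; beyond the scatter) from compound 2 to compound 3 and a 5.0-fold lower number (0.70 log units; beyond the scatter) from compound 1 to compound 4, at least 12-fold (1.11 log units) apart, beyond the scatter of two such steps This does not show why the direction reverses, and a single pair on each of two cores gives no general rule; the earlier step also rests on compound 3, whose entry is a limit and not a number: the limit of > 1000 nM in this assay, at which 1 of the 4 values shown sits.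

The compounds shown leave open which part of the difference between the two cores turns the effect of the change around. They also leave open how a bromo, trifluoromethyl or hydroxyl group in the same place, or a longer chain on either core, would behave in this assay.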